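One Ring Swap in a Small Growth-Inhibitor Series

The source may hold more compounds than are shown below. What is called first, only, known or untested is meant among the compounds shown, and "the series" means these compounds.

For the measured compounds named here, only two compounds have numbers so far in a functional assay on DU-145 cells (Homo sapiens) for inhibition, read by trypan blue exclusion, with a stated time of 96 h (on this read-out higher numbers stand for weaker inhibition of growth and lower numbers for stronger inhibition of growth), and compound 1 (`Cc1ccc(CS/C(=C/c2ccc(O)cc2)C(=O)c2ccc(Cl)cc2)cc1`) stands lowest at 10000 nM on that scale. Compound 2 (`Cc1ccsc1/C=C(/SCc1ccc(Cl)c(Cl)c1)C(=O)c1ccc(Cl)cc1`) gives 50000 nM as the higher number, a gap beyond the usual scatter, but the pair differs in more than one place. Compound 3 (`Cc1ccc(CS/C(=C/c2cc(C)ccc2C)C(=O)c2ccc(Cl)cc2)cc1`) has 2,5-dimethylphenyl in place of 4-hydroxyphenyl on a double-bonded chain carbon bound to a double-bonded chain carbon and keeps the rest of compound 1. Going by the values given here, no measured pair isolates this swap. Compound 2 at 50000 nM also lacks the 4-hydroxyphenyl group, which gives slight grounds to lean toward weaker inhibition. The expected change is modest, a 1.8-fold higher number from compound 1 to compound 3 (0.26 log units; within the scatter) in the direction of a higher number. For compound 3 the estimated value in this assay is 18000 nM with 5000 nM to 60000 nM as the expected range.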

Compound 3, concentration for 50% growth inhibition: 10000 nM
For compound 3 the middle estimate is 1.8-fold (0.26 log units) above the measured one; measured number inside the range.
By their numbers in this assay, from the lowest: compounds 1 and 3 (each within the scatter of the next); then compound 2.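

In this assay, putting 2,5-dimethylphenyl in place of 4-hydroxyphenyl on a double-bonded chain carbon bound to a double-bonded chain carbon gives no change at the digits printed from compound 1 to compound 3 (within the scatter). For the compounds shown here, this is the first comparison that changes one place only, and it shows that the number at this position holds even though the entering group carries 0 hydrogen-bond donors and 0 hydrogen-bond acceptors, against 1 of each in the group that leaves. Nothing available explains why the two groups give the same reading.

Going by these compounds, whether a phenyl ring carrying an amine or a carboxylic acid would read the same at this position remains open. The two methyl groups and the hydroxyl also changed together, so the compounds shown cannot tell what each contributes alone.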